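Swapping fluoro for nitro at a cytotoxicity limit

The source may report more compounds than this note shows. Statements on the series, on what has been measured and on what is new or still open speak of the compounds shown alone.

- Compound 1 `Cc1ccc(-c2csc(N3N=C(c4ccc(C)s4)CC3c3ccc(F)cc3)n2)cc1`: > 500 ug/mL
- Compound 2 `Cc1ccc(C2=NN(c3nc(-c4ccc(F)cc4)cs3)C(c3ccc(F)cc3)C2)s1`: > 500 ug/mL
- Compound 3 `Fc1ccc(C2CC(c3ccc(Cl)s3)=NN2c2nc(-c3ccc(C(F)(F)F)cc3)cs2)cc1`: > 500 ug/mL

All three compounds were tested in an ADME assay on NIH3T3 cells (Mus musculus) for cytotoxicity, read by XTT assay, with a stated time of 24 h; a higher number here means a weaker inhibitor, a lower number a stronger inhibitor. Compound 2, the starting point here, gives > 500 ug/mL. This is a limit of the assay and not a number. Compound 1 gives > 500 ug/mL, which is also a limit. Compound 3 gives > 500 ug/mL, again a limit. Compound 2 therefore has no exact position among the three, and the data so far amount to the limit of > 500 ug/mL in this assay, at which 3 of the 3 values shown sit.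

Compound 4 `Cc1ccc(C2=NN(c3nc(-c4ccc([N+](=O)[O-])cc4)cs3)C(c3ccc(F)cc3)C2)s1` has not yet been measured. It carries nitro in place of fluoro on an aromatic carbon, para to a large group, a change from 4-fluorophenyl to 4-nitrophenyl: nitro in place of fluoro on an aromatic carbon.

Going by the values given here, the one measured step that bears on this change is a step that the two limits leave unreadable from compound 1 to compound 2. It also replaces a single group on an aromatic carbon, but it has no readable size, so it offers no measured effect to carry over. With compound 2 at the limit of > 500 ug/mL, no shift in either direction can be predicted from these data. The expected change is a number no higher from compound 2 to compound 4 (the limit leaves the size open), which is estimated to be none beyond the scatter. The estimate for compound 4 is 500 ug/mL, with an expected range from 250 ug/mL to 1000 ug/mL.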

Compound 4, half-maximal inhibitory concentration: 15.6 ug/mL
Beside the measured number, compound 4's estimate is 32-fold (1.51 log units) above it; measured number outside the range, below it.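

In this assay, putting nitro in place of fluoro, the change from 4-fluorophenyl to 4-nitrophenyl, gives an at least 32-fold lower number from compound 2 to compound 4 (1.50 log units; beyond the scatter), which shows that a change at this place, para to a large group, can move the number far beyond the scatter. Going by these compounds alone, the step with nitro in place of methyl points the same way, as an at least 32-fold lower number from compound 1 to compound 4 (1.50 log units; beyond the scatter), whereas the step between compound 1 and compound 2 cannot be read, so the earlier compounds showed no effect of any size at this place. Compound 4 is also the only compound of the four with an exact value, and the others give only a limit: the limit of > 500 ug/mL in this assay, at which 3 of the 4 values shown sit.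

The compounds shown leave open whether this large drop belongs to nitro alone or would also appear with another group at the same place, such as an amine, a nitrile or a carboxylic acid. As far as these compounds go, the full size of both readable steps also stays unknown, and so does how much fluoro and methyl differ from each other, since each of those two compounds gives only a limit.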